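Working notes: from compound 3 to compound 4

The source may report more compounds than this note shows. Statements on the series, on what has been measured and on what is new or still open speak of the compounds shown alone.

Measured so far in an ADME assay on HEK293 cells (Homo sapiens) for cytotoxicity, read by ATP content, with a stated time of 6 h; on this read-out higher numbers stand for lower toxicity in this test and lower numbers for higher toxicity in this test
compound 1 `CCCCNc1nc(N)nc2ccn(Cc3ccccn3)c12` gives > 24000 nM as a limit
compound 2 `COCCCNc1nc(N)nc2ccn(Cc3ccccn3)c12` gives > 24000 nM as a limit
compound 3 `CC(Nc1nc(N)nc2ccn(Cc3ccccn3)c12)c1ccccn1` gives > 24000 nM as a limit

Compound 3 stands only at a limit (> 24000 nM) and takes no rank in the series. Going by the values given here, the series so far shows the limit of > 24000 nM in this assay, at which 3 of the 3 values shown sit, and nothing finer.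

Compound 4 `Cc1nnc(CNc2nc(N)nc3ccn(Cc4ccccn4)c23)o1` carries (5-methyl-1,3,4-oxadiazol-2-yl)methyl in place of 1-(pyridin-2-yl)ethyl on a nitrogen on an aromatic ring.

Two measured steps act at that same nitrogen: a step that the two limits leave unreadable from compound 1 to compound 3 and a step that the two limits leave unreadable from compound 2 to compound 3 are the closest guides. A third, a step that the two limits leave unreadable from compound 1 to compound 2 lies within the chain. None of the three has a readable size, so no measured size carries over to the new group. Among the compounds with values here, three different groups on that nitrogen all gave the limit, and no measured compound goes against this. In this assay no step beyond the scatter is therefore expected, and a further limit is the likeliest report. The step expected is a number no higher from compound 3 to compound 4 (the limit leaves the size open) in this estimate. For compound 4 the estimate is 24000 nM with an expected range from 16000 nM to 36000 nM in this assay.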

Compound 4, half-maximal cytotoxic concentration: > 24000 nM
Compound 4 was reported as a limit; the forecaster's own chance of this, stated with the estimate: 90%; the middle value sits exactly at the limit.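

Compound 4 is reported only as a limit in this assay, so no step from compound 1, compound 2 or compound 3 to compound 4 can be read, and the series still shows only this: the limit of > 24000 nM in this assay, at which 4 of the 4 values shown sit.

The compounds shown leave open what actual value any of them would give, and whether any group on that nitrogen changes the read-out.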